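A Second Chloro on the Core of Compound 1

The source may hold more compounds than are shown below. What is called first, only, known or untested is meant among the compounds shown, and "the series" means these compounds.

Compound 1 `ClCc1ccccc1Cn1cnc2ncnc(Cl)c21` is one of three compounds tested in a functional assay on NCI/ADR-RES cells (Homo sapiens) for cytotoxicity, read by sulforhodamine B assay, with a stated time of 48 h (a higher number here means a weaker inhibitor of growth, a lower number a stronger inhibitor of growth), where compound 1 gives 2080 nM. Its two companions share the same fused core but carry different substituents. Compound 3 `Nc1nc(Cl)c2ncn(Cc3ccccc3CCl)c2n1`, with an amino group on the six-membered ring, gives 4470 nM in this assay, a higher number than that of compound 1, with the gap beyond the usual scatter. Compound 2 `ClCc1ccc(Cn2cnc3c(Cl)nc(Cl)nc32)cc1`, which has two chloro groups on the core and its chloromethyl group at a different position on the benzyl ring, gives 16600 nM, the highest of the three. Compound 1 therefore stands lowest, and both gaps lie beyond the scatter.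

Compound 4 `ClCc1ccccc1Cn1cnc2nc(Cl)nc(Cl)c21` differs from compound 1 by a single change: chloro in place of hydrogen on an aromatic carbon. Among the measured compounds shown here, no pair of measured compounds isolates this change, since compound 2 also differs from compound 1 in its benzyl group. A modest rise in the number, close to the scatter, is expected, so compound 4 is estimated at 3200 nM, within 1200 nM to 8500 nM, a step of a 1.5-fold higher number from compound 1 to compound 4 (0.19 log units; within the scatter).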

Compound 4, concentration for 50% growth inhibition: 2340 nM
The estimate for compound 4 lay 1.4-fold (0.14 log units) above the measured number, within the range that was stated.
By their numbers in this assay, from the lowest: compounds 1, 4 and 3 (each within the scatter of the next, the first and the last beyond it); then compound 2.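

Putting chloro in place of hydrogen on the aromatic carbon between two ring nitrogen atoms gives, in this assay, a 1.1-fold higher number from compound 1 to compound 4 (0.05 log units; within the scatter), so the two compounds cannot be told apart. Among the compounds shown here, this is the first direct reading of this single change, as none of the earlier compounds isolated it, and it shows that this carbon can carry a chloro group with no measurable loss of growth inhibition on these cells. Nothing available here explains this outcome.

On these data alone, it remains open whether a larger or differently built group on this carbon, such as a methyl group, a methoxy group or a carboxylic acid, would also leave the number within the scatter. As far as these compounds go, it is equally open whether the same chloro change would give a similar result with the chloromethyl group placed elsewhere on the benzyl ring.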